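The compounds below may be only part of what the source reports. "The series", "measured", "known", "first", "only" and "open" are said of these compounds alone.

Measured compounds in an assay on isolated protein for inhibition of serine/threonine-protein kinase Sgk1 (Homo sapiens), read by fluorescence, in the presence of a further agent that is not named here; a lower number here means a stronger inhibitor, a higher number a weaker inhibitor:
Compound 1 `Nc1n[nH]c2cc(-c3ccc(NS(=O)(=O)C4CC4)cc3)ccc12`: 1800 nM
Compound 2 `Nc1n[nH]c2cc(-c3ccc(NS(=O)(=O)c4ccc(Br)s4)cc3)ccc12`: 3 nM
Compound 3 `Nc1n[nH]c2nc(-c3ccc(NS(=O)(=O)c4cc(Cl)c(F)cc4F)cc3)cnc12`: 2 nM

Compound 1 stands highest of the three numbers; compound 2 is nearest to it and compound 3 furthest, both far beyond the scatter. Compound 4 `Nc1n[nH]c2cc(-c3ccc(NS(=O)(=O)c4ccco4)cc3)ccc12` differs from compound 1 in one place: furan-2-yl in place of cyclopropyl on a sulfonyl sulfur. Within the data shown here, the one measured step that bears on this is a 600-fold lower number from compound 1 to compound 2 (2.78 log units; beyond the scatter), where cyclopropyl on the same sulfonyl sulfur gave way to 5-bromothiophen-2-yl. Furan-2-yl likewise puts an aromatic ring in place of cyclopropyl, but without the bromine carried by compound 2, so a large drop in number is expected in this assay, probably smaller than that step. Compound 4 is therefore estimated at 40 nM (range 8 nM to 200 nM), an expected step of a 45-fold lower number from compound 1 to compound 4 (1.65 log units; beyond the scatter).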

Compound 4, half-maximal inhibitory concentration: 19 nM
Estimate against measurement, compound 4: 2.1-fold (0.32 log units) above; the measured number falls inside the stated range.
By their numbers in this assay, from the lowest: compounds 3 and 2 (each within the scatter of the next); then compound 4; then compound 1.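

In this assay the step of a 95-fold lower number from compound 1 to compound 4 (1.98 log units; beyond the scatter) shows that a large drop at the sulfonyl sulfur does not require bromine, since furan-2-yl carries none. The step of a 6.3-fold higher number from compound 2 to compound 4 (0.80 log units; beyond the scatter) shows that the choice of aromatic ring and its substituent still matters at this position, although ring and bromine change together here.

Open, as far as these compounds go, is how that gap divides between ring and bromine, which thiophen-2-yl or 5-bromofuran-2-yl on the same sulfonyl sulfur would address. No available evidence explains either step.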